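The compounds below may be only part of what the source reports. "The series", "measured", "known", "first", "only" and "open" are said of these compounds alone.

Within the data shown here, the shared core of compound 1 `COc1cc(-c2nnc(SCc3cccc(Cl)c3)o2)ccc1O` and compound 2 `COc1cc(-c2nnc(SCc3ccc(Br)cc3)o2)ccc1O` carries a hydroxy group that is left untouched in the one measured step. In an ADME assay on cells (Mus musculus, strain BALB/c) for cytotoxicity, read by MTT assay, with a stated time of 24 h (on this read-out lower numbers stand for higher toxicity in this test and higher numbers for lower toxicity in this test), compound 1 gives 470000 nM, and in this assay compound 2 gives 455000 nM. The step of a 1.0-fold lower number from compound 1 to compound 2 (0.01 log units; within the scatter) shows that exchanging the halogenated phenyl on the saturated chain carbon bound to a sulfur left the read-out where it was. Among the measured compounds shown here, compound 2 thus has the lowest of the two numbers known so far, with compound 1 only a hair apart and within the scatter of it, so no order between the two can be claimed.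

Compound 3 `COc1cc(-c2nnc(SCc3ccc(Br)cc3)o2)ccc1OCc1ccc(Br)cc1` differs from compound 2 in a single place: 4-bromobenzyl in place of hydrogen on an oxygen on an aromatic ring. For the measured compounds named here, no measured step touches this oxygen, so the one step known, which concerns a different site, gives no direct guide. With nothing in the data pointing either way, the number for compound 3 is expected to stay close to that of compound 2, a step of a 1.3-fold lower number from compound 2 to compound 3 (0.11 log units; within the scatter). Compound 3 is therefore estimated at 350000 nM, within a range from 150000 nM to 700000 nM.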

Compound 3, half-maximal cytotoxic concentration: 225000 nM
The estimate for compound 3 lay 1.6-fold (0.19 log units) above the measured number, and the stated range covers the measured number.
By their numbers in this assay, from the lowest: compound 3; then compounds 2 and 1 (each within the scatter of the next).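

Among these compounds, putting 4-bromobenzyl in place of hydrogen on the oxygen on an aromatic ring gives, in this assay, a 2.0-fold lower number from compound 2 to compound 3 (0.31 log units; beyond the scatter) and is the first step here to pass beyond the scatter, so this oxygen is a place where the read-out does respond, though only modestly, and it responds towards higher toxicity in this test. Among the compounds shown here, the change is a bulky one in its count, since 8 heavy atoms enter at once, among them a six-membered aromatic ring and a bromine, so the single step cannot separate the loss of the hydroxy hydrogen from the arrival of the ring or of the bromine. Nothing available explains why the number moved.

The compounds shown leave open whether a small methyl or an unsubstituted benzyl on this oxygen would shift the number as 4-bromobenzyl does, or whether a chain ending in an amine or a carboxylic acid would shift it the other way. They also leave open whether the same exchange on compound 1, with its 3-chlorophenyl, would give a step of similar size.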